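Compound 3 to compound 4: clearance at the assay limit

The source may hold more compounds than are shown below. What is called first, only, known or untested is meant among the compounds shown, and "the series" means these compounds.

In an ADME assay on microsomes from liver (Homo sapiens) for metabolic stability, read by LC-MS, with a stated time of 40 min, tested at 0.5 uM (on this read-out lower numbers stand for slow clearance and higher numbers for fast clearance), compound 3 (`O=C(Nc1cccc(S(=O)(=O)NC2CC2)c1)c1cccnc1N1CCC2(CC1)CC2`) gives > 399 mL.min-1.g-1, which is a limit and not a number. Compound 2 (`CC(C)(C)NS(=O)(=O)c1cccc(NC(=O)c2cccnc2N2CCC3(CC2)CC3)c1`) gives > 399 mL.min-1.g-1, also a limit. Compound 1 (`O=C(Nc1cccc(S(=O)(=O)C2CCCC2)c1)c1cccnc1N1CCC(F)(F)CC1`), which also carries cyclopentyl on a sulfonyl sulfur, gives > 399 mL.min-1.g-1, again a limit.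

Compound 4 (`O=C(Nc1cccc(S(=O)(=O)C2CCCC2)c1)c1cccnc1N1CCC2(CC1)CC2`) differs from compound 3 by one change: cyclopentyl in place of cyclopropylamino on a sulfonyl sulfur. In words, this is cyclopentyl in place of cyclopropylamino on a sulfonyl sulfur.

For the measured compounds named here, the only measured step, a step that the two limits leave unreadable from compound 2 to compound 3, offers no size to carry over. Compound 1 and compound 3 both rest at the limit of > 399 mL.min-1.g-1 in this assay, at which 3 of the 3 values shown sit. No direction is expected in this assay for the estimated step that the limit leaves unreadable from compound 3 to compound 4, and its size remains poorly defined. For compound 4 the estimate is 500 mL.min-1.g-1, with an expected range of 300 mL.min-1.g-1 to 900 mL.min-1.g-1, and a further report as a limit is considered likely.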

Compound 4, intrinsic clearance in microsomes: > 399 mL.min-1.g-1
Compound 4: only a limit was reported; the forecaster's own chance of this, stated with the estimate: 80%; the middle value lies beyond the limit too.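

Compound 4 gives > 399 mL.min-1.g-1 in this assay, a limit and not a number. No step from compound 1, compound 2 or compound 3 to compound 4 can be read: the limit of > 399 mL.min-1.g-1 in this assay, at which 4 of the 4 values shown sit.

Going by these compounds, the actual clearance of all four compounds, and so any difference among them, stays open.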